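Hydroxy in place of hydrogen on a saturated ring carbon

The source may hold more compounds than are shown below. What is called first, only, known or untested is meant among the compounds shown, and "the series" means these compounds.

Measured compounds in an assay on HEK293 cells for agonist activity at Bile acid receptor (Homo sapiens); on this read-out higher numbers stand for larger maximal responses and lower numbers for smaller maximal responses:
compound 1, `O=C(O)c1cccc([C@H]2C[C@@H](c3ccc(OCc4c(-c5c(Cl)cccc5Cl)noc4C4CC4)cc3Cl)C2)c1`, 88%
compound 2, `O=C(O)c1cccc([C@H]2C[C@@H]2c2ccc(OCc3c(-c4c(Cl)cccc4Cl)noc3C3CC3)cc2Cl)c1`, 88%

Compound 1 stands level with compound 2 at the digits shown; the nearest measured neighbour is compound 2, and the two values show no change beyond the usual scatter. Both measured compounds reach a large maximal response in this assay.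

Compound 3, `O=C(O)c1cccc([C@H]2C[C@](O)(c3ccc(OCc4c(-c5c(Cl)cccc5Cl)noc4C4CC4)cc3Cl)C2)c1`, is the next compound and is not yet measured. It differs from compound 1 by hydroxy in place of hydrogen on a saturated ring carbon.

Going by the values given here, no step between measured compounds is known that would guide the size of this change. Given that compound 1 reaches 88%, the maximal response of compound 3 is expected to stay close to that level, with at most a modest drop and most likely no step beyond the scatter; the expected step is a number 6 percentage points lower from compound 1 to compound 3 (within the scatter). For compound 3 the estimate is 82%, with a range from 62% to 98%.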

Compound 3, largest response reached (reported as efficacy), in percent of the reference or control that the assay uses: 79%
For compound 3 the middle estimate is 3 percentage points above the measured one; measured number inside the range.
By their numbers in this assay, from the lowest: compounds 3, 1 and 2 (each within the scatter of the next).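

The first substituent shown on this ring carbon, which is two ring bonds from the ring atom bearing the 3-carboxyphenyl group, gives a first reading of the position: in this assay, hydroxy in place of hydrogen gives a number 9 percentage points lower from compound 1 to compound 3 (within the scatter). The added hydrogen-bond donor and acceptor at this carbon therefore leave the maximal response within the scatter, with compound 3 at 79%. Nothing on hand accounts for this result.

As far as these compounds go, how an amine, a methoxy group or a fluorine on the same ring carbon would read in this assay remains open. Also open, from the compounds shown here alone, is whether hydroxy on the opposite face of the four-membered ring would read like compound 3, and whether either compound differs in potency, which a maximal response does not show.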